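Replacing isopropyl with cyclohexylmethyl in compound 3

The compounds below may be only part of what the source reports. "The series", "measured", "known", "first", "only" and "open" are said of these compounds alone.

In a functional assay (strain AB) with Danio rerio as the target, read by microscopy, with a stated time of 1 h (on this read-out lower numbers stand for an effect already at smaller amounts and higher numbers for an effect only at larger amounts of compound), three compounds sharing one core have been measured. Compound 1 `CC(C)(C)OC(=O)CCCC[N+]1(C)CCc2c(sc(NC(=O)Nc3ccc(Cl)cc3)c2C(N)=O)C1` gives 140 nM, compound 2 `CC(C)(C)OC(=O)CCC[N+]1(C)CCc2c(sc(NC(=O)Nc3ccc(Cl)cc3)c2C(N)=O)C1` gives 250 nM, and compound 3 `CC(C)[N+]1(C)CCc2c(sc(NC(=O)Nc3ccc(Cl)cc3)c2C(N)=O)C1` gives 960 nM. Compound 3 thus has the highest number of the three, and its gaps to both others lie beyond the scatter.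

The unmeasured compound 4 `C[N+]1(CC2CCCCC2)CCc2c(sc(NC(=O)Nc3ccc(Cl)cc3)c2C(N)=O)C1` carries cyclohexylmethyl in place of the isopropyl of compound 3 on an amine nitrogen in a ring: cyclohexylmethyl in place of isopropyl on an amine nitrogen in a ring. For the measured compounds named here, two measured steps bear on this change, each ending at isopropyl on that same nitrogen, and read in reverse they point to a lower number on leaving isopropyl: a 6.9-fold higher number from compound 1 to compound 3 (0.84 log units; beyond the scatter) and a 3.8-fold higher number from compound 2 to compound 3 (0.58 log units; beyond the scatter), both modest. The remaining step, a 1.8-fold higher number from compound 1 to compound 2 (0.25 log units; within the scatter), stays within the scatter. Going by the values given here, the guidance is limited, however: the groups in compound 1 and compound 2 both carry tert-butoxycarbonyl, which cyclohexylmethyl lacks, and no measured compound has a ring in this group.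

A modest move toward a lower number is therefore expected, somewhat smaller than the two measured steps, with the expected step being a 2.1-fold lower number from compound 3 to compound 4 (0.33 log units; beyond the scatter). For compound 4 the estimated value is 450 nM, with an expected range of 150 nM to 1300 nM.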

Compound 4, half-maximal effective concentration: 100 nM
Compound 4: middle estimate off by 4.5-fold (0.65 log units), on the high side, and the stated range ends above it.
By their numbers in this assay, from the lowest: compounds 4, 1 and 2 (each within the scatter of the next, the first and the last beyond it); then compound 3.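

In this assay, the change from isopropyl to cyclohexylmethyl on the amine nitrogen in the ring brings a 9.6-fold lower number from compound 3 to compound 4 (0.98 log units; beyond the scatter), which shows that a low number at this position does not depend on tert-butoxycarbonyl, since the entering group consists of carbon only and has no hydrogen-bond acceptors. The ring-bearing group also gives a 2.5-fold lower number from compound 2 to compound 4 (0.40 log units; beyond the scatter), whereas the comparison with the longest ester-bearing chain gives a 1.4-fold lower number from compound 1 to compound 4 (0.15 log units; within the scatter), so compound 4 and compound 1 cannot be told apart despite their very different groups on this nitrogen. No measurement shown here accounts for the size of the step from isopropyl to cyclohexylmethyl.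

Because cyclohexylmethyl brings a ring and more carbon atoms together, these compounds leave open which of the two matters, a question that an open heptyl chain or a cyclohexyl placed directly on the nitrogen could separate. On these data alone, it also remains open how the number would respond to a benzyl group, or to a carboxylic acid or an amine at the end of the chain in place of tert-butoxycarbonyl.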